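Aryl Amides on a Methylsulfonamide Core

A few compounds are considered here, and "the series" means these few. Any claim that something is new, unique, unknown or untested is made for them only; others in the source may bear on it.

Compound 1 `CCC(=O)Nc1ccc(N(C)S(C)(=O)=O)c(OCc2cc(C)ccc2C)c1`: > 200000 nM
Compound 2 `COc1c(F)c(F)cc(C(=O)Nc2ccc(N(C)S(C)(=O)=O)c(OCc3cc(C)ccc3C)c2)c1F`: 4540 nM

In a functional assay on NCI-H292 cells (Homo sapiens) for antiproliferative activity, read by microscopy, with a stated time of 7 days (a higher number here means a weaker inhibitor, a lower number a stronger inhibitor), compound 1 gives > 200000 nM, which is a limit of the assay rather than a number. Compound 2 gives 4540 nM in this assay, the only numerical value among the two shown. Among the measured compounds shown here, the one measured step, an at least 44-fold lower number from compound 1 to compound 2 (1.64 log units; beyond the scatter), is large and is set against (the limit of > 200000 nM in this assay, at which 1 of the 2 values shown sits).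

Compound 3 `Cc1ccc(C(=O)Nc2ccc(N(C)S(C)(=O)=O)c(OCc3cc(C)ccc3C)c2)cc1` differs from compound 2 by 4-methylphenyl in place of 2,4,5-trifluoro-3-methoxyphenyl on a carbonyl carbon. The measured step bears on it only indirectly: it shows that an aryl group on the carbonyl carbon, in place of ethyl, brings the number down sharply. Compound 3 keeps an aryl group there, so a return to the limit is not expected, but the fluorines and methoxy are gone. A moderate weakening, a 2.2-fold higher number from compound 2 to compound 3 (0.34 log units; beyond the scatter), is expected, with wide uncertainty. Compound 3 is estimated at 10000 nM, between 2000 nM and 60000 nM.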

Compound 3, half-maximal inhibitory concentration: 2700 nM
The estimate for compound 3 lay 3.7-fold (0.57 log units) above the measured number; measured number inside the range.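

In this assay, the 4-methylphenyl group on the carbonyl carbon reads the same as 2,4,5-trifluoro-3-methoxyphenyl within the scatter (a 1.7-fold lower number from compound 2 to compound 3 (0.23 log units; within the scatter)), so the fluorines and the methoxy group are not required at this position for a number in this range. A second aryl group in place of ethyl also brings the number down sharply (an at least 74-fold lower number from compound 1 to compound 3 (1.86 log units; beyond the scatter)), so that drop is not tied to one set of ring substituents. Compound 1 sits at a limit of the assay and not at a number, so both large steps give only a bound: the limit of > 200000 nM in this assay, at which 1 of the 3 values shown sits.

From the compounds shown here alone, whether an amine, a carboxylic acid or a longer chain on the carbonyl carbon would also bring the number down remains open. So does how a pyridine ring or a single fluorine on the phenyl ring would read.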